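Compound 4: methyl in place of fluoro on compound 1

A few compounds are considered here, and "the series" means these few. Any claim that something is new, unique, unknown or untested is made for them only; others in the source may bear on it.

Compound 1 `COc1cc2ncnc(NNC(=S)NC(=O)c3ccc(F)cc3)c2cc1OC` gives 15300 nM in a functional assay on GLC82 cells (Homo sapiens) for cytotoxicity, read by MTT assay, with a stated time of 72 h (a lower number here means a stronger inhibitor, a higher number a weaker inhibitor), the highest of the three numbers obtained so far. Compound 2 `COc1ccccc1C(=O)NC(=S)NNc1ncnc2ccccc12` gives 9500 nM in this assay, a gap to compound 1 that stays within the scatter. Compound 3 `O=C(NC(=S)NNc1ncnc2ccccc12)c1ccc(Cl)cc1` gives 6680 nM in this assay, and here the gap to compound 1 lies beyond the scatter. Going by the values given here, the only single-point step measured, a 1.4-fold lower number from compound 2 to compound 3 (0.15 log units; within the scatter), alters the aromatic ring attached to the carbonyl, the same ring that is altered in the step considered here, and it stays within the scatter.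

Compound 4 `COc1cc2ncnc(NNC(=S)NC(=O)c3ccc(C)cc3)c2cc1OC` differs from compound 1 in one place: methyl in place of fluoro on an aromatic carbon. Among the compounds with values here, no measured pair swaps fluoro for methyl, so the expectation rests on the shared core of compound 1 and on the one step measured on that ring, which moved the number only within the scatter. The step expected from this change, a 1.2-fold lower number from compound 1 to compound 4 (0.07 log units; within the scatter), is therefore small, with no direction that would reach beyond the scatter. The estimate for compound 4 in this assay is 13000 nM, with a range from 5500 nM to 32000 nM.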

Compound 4, half-maximal inhibitory concentration: 29900 nM
Compound 4: the middle estimate sits 2.3-fold (0.36 log units) below what was measured, within the range that was stated.
By their numbers in this assay, from the lowest: compounds 3, 2, 1 and 4 (each within the scatter of the next, the first and the last beyond it).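

In this assay, going by these compounds alone, the change from 4-fluorophenyl to 4-methylphenyl gives a 2.0-fold higher number from compound 1 to compound 4 (0.29 log units; within the scatter) and is the first single change read on the core of compound 1. At this place, para to a large group, one heavy atom is exchanged for another with no hydrogen-bond donor or acceptor on either side, and the two compounds are not separated. Together with a 1.4-fold lower number from compound 2 to compound 3 (0.15 log units; within the scatter) on a different core, this gives two steps on the aromatic ring attached to the carbonyl, both within the scatter, so no single change on that ring has yet been shown to go beyond it, and nothing available bears on the cause of the new step.

The compounds shown leave open whether an amine, a carboxylic acid or a longer chain such as butyl at this place would give a step beyond the scatter. Within the data shown here, they also leave open whether fluoro and methyl would behave alike on the core of compound 3, since no pair here differs only in that core.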